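The source may report more compounds than this note shows. Statements on the series, on what has been measured and on what is new or still open speak of the compounds shown alone.

Going by the values given here, in a functional assay on cells (Neutrophil, Homo sapiens) for inhibition, with a stated time of 10 min (a higher number here means a weaker inhibitor, a lower number a stronger inhibitor), compound 3 `CCOC(=O)c1cnn(CC(O)CC)c1NC(=O)Nc1ccccc1F` gives 0.0016 nM, the second highest of the three numbers so far. The number is lower for compound 2 `CCOC(=O)c1cnn(CC(C)O)c1NC(=O)NCc1ccccc1`, which gives 0.00054 nM. It is higher for compound 1 `CCOC(=O)c1cnn(CC(C)O)c1NC(=O)Nc1ccc(F)cc1`, which gives 0.2 nM. The next compound, compound 4 `CCOC(=O)c1cnn(CC(O)CC)c1NC(=O)Nc1ccc(F)cc1`, keeps the side chain of compound 3 and moves the fluorine of the aryl group: 4-fluorophenyl in place of 2-fluorophenyl on an amide-type nitrogen. Among the compounds with values here, only one measured step bears on this nitrogen, a 370-fold lower number from compound 1 to compound 2 (2.57 log units; beyond the scatter), and it shows that this assay can respond strongly to a change there. That step swaps in benzyl rather than moving a fluorine, so it is only indirect guidance. The closer clue is that compound 1, which also carries 4-fluorophenyl, reads 0.2 nM. A sizeable rise in the number is therefore expected, though probably not the full gap up to compound 1. The expected change is a 25-fold higher number from compound 3 to compound 4 (1.40 log units; beyond the scatter). For compound 4 the estimated value is 0.04 nM, with an expected range from 0.004 nM to 0.4 nM.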

Compound 4, half-maximal inhibitory concentration: 1.9 nM
Compound 4: middle estimate off by 48-fold (1.68 log units), on the low side, outside the stated range (above it).
By their numbers in this assay, from the lowest: compound 2; then compound 3; then compound 1; then compound 4.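

In this assay, moving the fluorine alone, with the atoms on the amide-type nitrogen otherwise unchanged, gives a 1200-fold higher number from compound 3 to compound 4 (3.07 log units; beyond the scatter), so this position responds strongly to where the fluorine sits on the aryl group and not only to a swap of the whole group. The side chain also matters with 4-fluorophenyl held fixed: methyl in place of hydrogen on a saturated chain carbon, two bonds along the chain from an oxygen on a saturated carbon, gives a 9.5-fold higher number from compound 1 to compound 4 (0.98 log units; beyond the scatter), a modest step beside the large one from the fluorine move. Nothing measured here accounts for either step.

As far as these compounds go, it remains open where a plain phenyl group on this nitrogen would fall relative to the two fluorophenyl groups. From the compounds shown here alone, whether the same methyl change would shift the number in the same direction with 2-fluorophenyl also remains open.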